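A few compounds are considered here, and "the series" means these few. Any claim that something is new, unique, unknown or untested is made for them only; others in the source may bear on it.

Working notes on the series. Compound 1 `CC(C)(O)CCCn1c(Cn2c(=O)n(C3CC3)c3ccncc32)nc2nc(Cl)ccc21` carries a 4-hydroxy-4-methylpentyl chain on a nitrogen of its core. In an ADME assay on HeLa cells (Homo sapiens) for cytotoxicity, read by ATP content, with a stated time of 3 days (on this read-out higher numbers stand for lower toxicity in this test and lower numbers for higher toxicity in this test), compound 1 gives > 50000 nM, which is a limit of the assay and not a number. Compound 2 `N#CCCCn1c(Cn2c(=O)n(-c3ccc(C(=O)NC4CC4)cc3)c3ccncc32)cc2cc(Cl)ccc21` has a different core and a different chain. In this assay compound 2 gives > 50000 nM, again a limit of the assay rather than a number. Among the measured compounds shown here, compound 1 therefore stands at the limit of > 50000 nM in this assay, at which 2 of the 2 values shown sit, and no step between compounds that differ in one place has been measured. Compound 3 `N#CCCCn1c(Cn2c(=O)n(C3CC3)c3ccncc32)nc2nc(Cl)ccc21` is the analog of compound 1 in which (cyano in place of 1-hydroxy-1-methylethyl on a saturated chain carbon, three bonds along the chain from an aromatic nitrogen). For the measured compounds named here, no measured step covers this change, so the only guide is that both values shown reach the limit. No movement beyond the scatter is expected in this assay for this change. The step expected is a step that the limit leaves unreadable from compound 1 to compound 3. Compound 3 is estimated at 80000 nM in this assay, within 30000 nM to 250000 nM, and it is most likely to be reported again only as a limit.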

Compound 3, half-maximal cytotoxic concentration: > 50000 nM
Compound 3 ended at the assay's limit (the forecaster's own chance of this, stated with the estimate: 85%); the middle value is on the limit's open side.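

No step can be read from compound 1 to compound 3 in this assay, since both reach the limit of the assay: the limit of > 50000 nM in this assay, at which 3 of the 3 values shown sit.

The compounds shown leave open whether cyano in place of 1-hydroxy-1-methylethyl changes the half-maximal cytotoxic concentration at all, and what actual number compound 1, compound 2 or compound 3 would give beyond that limit.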